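The compounds below may be only part of what the source reports. "The series", "measured", "known", "first", "only" and "open" are said of these compounds alone.

Measured compounds:
Compound 1 `N#C/C(=C\c1ccc[nH]1)C(=O)NCc1ccc(Cl)c(Cl)c1` gives > 50000 nM in a functional assay on A2780 cells (Homo sapiens) for inhibition, read by MTT assay, with a stated time of 72 h (on this read-out lower numbers stand for stronger inhibition of growth and higher numbers for weaker inhibition of growth), a limit of the assay rather than a number.
Compound 2 `N#C/C(=C\c1ccco1)C(=O)NCc1ccc(Cl)c(Cl)c1` gives > 50000 nM in this assay, again only a limit.

Both results sit at the same limit (the limit of > 50000 nM in this assay, at which 2 of the 2 values shown sit), so the step that the two limits leave unreadable from compound 1 to compound 2 cannot be read in either direction. Compound 3 `N#C/C(=C\c1ccccc1)C(=O)NCc1ccc(Cl)c(Cl)c1` differs from compound 2 by phenyl in place of furan-2-yl on a double-bonded chain carbon bound to a double-bonded chain carbon. No readable step exists to guide the direction, and compound 2 itself is known only as a limit. Compound 3 is therefore expected to remain at that limit, an expected step of a number no higher from compound 2 to compound 3 (the limit leaves the size open) not beyond the scatter. The estimate for compound 3 is 50000 nM, expected between 20000 nM and 200000 nM.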

Compound 3, concentration for 50% growth inhibition: 49000 nM
For compound 3 the middle estimate is 1.0-fold (0.01 log units) above the measured one; the measured number falls inside the stated range.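

Among these compounds, compound 3 is the first compound here to give a number rather than a limit in this assay, so this position now has one readable value. Replacing furan-2-yl with phenyl gives an at least 1.0-fold lower number from compound 2 to compound 3 (0.00 log units; that floor lies within the scatter), and replacing 1H-pyrrol-2-yl with phenyl gives an at least 1.0-fold lower number from compound 1 to compound 3 (0.00 log units; that floor lies within the scatter). Neither floor goes beyond the scatter, so no gain from phenyl can be claimed.

From the compounds shown here alone, it remains open whether an amine, a carboxylic acid or a longer chain at this place would give a clearly lower number. Going by these compounds, the true distance of compound 1 and compound 2 from compound 3 also stays open: both are known only as limits.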